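Dropping one methoxy group from compound 1

A few compounds are considered here, and "the series" means these few. Any claim that something is new, unique, unknown or untested is made for them only; others in the source may bear on it.

Three related compounds have been measured in a physicochemical assay for lipophilicity, measured as octanol-water partition; on this read-out higher numbers stand for higher lipophilicity and lower numbers for lower lipophilicity. Compound 1 `COc1cc(/C=N/NC(=O)COc2cccc3ccccc23)cc(OC)c1OC` gives 3.26 in this assay. Compound 2 `O=C(COc1cccc2ccccc12)N/N=C/c1c(O)ccc2ccccc12` gives 4.74, and compound 3 `O=C(COc1cccc2ccccc12)N/N=C/c1ccccc1[N+](=O)[O-]` gives 3.97. Compound 1 thus stands lowest of the three numbers; its nearest neighbour is compound 3, which sits higher by a gap beyond the usual scatter, and compound 2 lies furthest away, higher again by a gap well beyond the scatter.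

The next compound, compound 4 `COc1ccc(/C=N/NC(=O)COc2cccc3ccccc23)cc1OC`, has not yet been measured in this assay. It differs from compound 1 in a single place: hydrogen in place of methoxy on an aromatic carbon. The rest of the molecule, including the shared core, is unchanged.

Going by the values given here, no pair of measured compounds differs in just one place, so nothing here shows directly what removing a methoxy group does in this assay. Going by the small size of what leaves and what enters, the step from compound 1 to compound 4 is expected to be a number 0.04 log units higher from compound 1 to compound 4 (within the scatter), which lies within the scatter. Compound 4 is therefore estimated at 3.3 in this assay. For compound 4 the range of that estimate runs from 2.9 to 3.7.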

Compound 4, partition coefficient: 3.51
For compound 4 the middle estimate is 0.21 log units below the measured one, and the stated range covers the measured number.
By their numbers in this assay, from the lowest: compounds 1 and 4 (each within the scatter of the next); then compound 3; then compound 2.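

Going by these compounds alone, this is the first pair in the set that differs in one place only, so it gives the first direct reading of what this change does in this assay. Putting hydrogen in place of methoxy on this aromatic carbon, ortho to a methoxy group, gives a number 0.25 log units higher from compound 1 to compound 4 (within the scatter), so compound 1 and compound 4 cannot be told apart on this read-out. At this position, then, taking away a methoxy group, with its two heavy atoms and one hydrogen-bond acceptor, leaves no change larger than the differences seen between repeated measurements. Nothing available here explains this result.

What the compounds shown leave open is whether this holds only for methoxy and hydrogen at this carbon, or also for other groups there, such as an amine, a carboxylic acid or a longer chain like butoxy. They also leave open whether removing the methoxy group at another place on the same ring would give a similar step, since this single pair speaks for one position alone.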